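The source may hold more compounds than are shown below. What is called first, only, known or untested is meant among the compounds shown, and "the series" means these compounds.

Measured in a functional assay on OVCAR-8 cells (Homo sapiens) for inhibition; a higher number here means a weaker inhibitor of growth, a lower number a stronger inhibitor of growth:
- compound 1 `NS(=O)(=O)c1ccc(/C=C/c2ccc(O)c(O)c2)cc1`: 16700 nM
- compound 2 `NS(=O)(=O)c1ccc(/C=C/c2ccc(F)cc2)cc1`: 15200 nM

Compound 2, at 15200 nM, lies within the scatter of compound 1, so the two cannot be ranked. The next compound to consider is compound 3 `NS(=O)(=O)c1ccc(/C=C/c2ccc(O)cc2)cc1`, which differs from compound 2 at one place: hydroxy in place of fluoro on an aromatic carbon, para to a large group (hydroxy in place of fluoro on an aromatic carbon). For the measured compounds named here, no measured pair isolates this exchange, so its effect in this assay is unknown. Going by the values given here, the only guide is compound 1, which also carries hydroxy and gives 16700 nM. On that basis, no change beyond the scatter is expected. The expected step is a 1.2-fold lower number from compound 2 to compound 3 (0.07 log units; within the scatter). Compound 3 is estimated at 13000 nM, with an expected range of 5500 nM to 30000 nM.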

Compound 3, concentration for 50% growth inhibition: 4810 nM
Beside the measured number, compound 3's estimate is 2.7-fold (0.43 log units) above it; the whole stated range lies above it.
By their numbers in this assay, from the lowest: compound 3; then compounds 2 and 1 (each within the scatter of the next).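

Within this assay the position para to a large group proves sensitive to the group it carries: hydroxy in place of fluoro gives a 3.2-fold lower number from compound 2 to compound 3 (0.50 log units; beyond the scatter) and makes compound 3 the strongest inhibitor of growth of the three. Compound 1 gave a poor guide to this change, since hydrogen in place of hydroxy on an aromatic carbon gives a 3.5-fold lower number from compound 1 to compound 3 (0.54 log units; beyond the scatter) and so the additional hydroxy of compound 1 goes with the loss of the lower number.

Going by these compounds, whether methoxy or an amine in place of hydroxy at this position would keep or extend the lower number remains open. No supporting data bear on why hydroxy differs from fluoro here, or on why the additional hydroxy reverses the gain.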